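The source may hold more compounds than are shown below. What is called first, only, known or untested is meant among the compounds shown, and "the series" means these compounds.

Working notes on the series in an ADME assay on THP-1 cells (Homo sapiens) for cytotoxicity, read by flow cytometry and propidium iodide staining, with a stated time of 72 h; on this read-out lower numbers stand for stronger inhibition and higher numbers for weaker inhibition.

Three compounds have numbers. Compound 1 `COc1ccc(-c2cc(=O)c3cc(N)ccc3o2)cc1` gives 124000 nM in this assay. Compound 2 `COc1c(-c2ccccc2)oc2ccc(N)cc2c1=O` gives 74000 nM in this assay. Compound 3 `COc1ccc(-c2oc3ccc(N)cc3c(=O)c2OC)cc1` gives 21000 nM in this assay, the lowest of the three numbers; the nearest of the others is compound 2 and the furthest is compound 1. Both single-point steps end at compound 3: a 5.9-fold lower number from compound 1 to compound 3 (0.77 log units; beyond the scatter) and a 3.5-fold lower number from compound 2 to compound 3 (0.55 log units; beyond the scatter), each a methoxy in place of hydrogen on an aromatic carbon.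

The next compound, compound 4 `COc1c(-c2ccc(F)cc2)oc2ccc(N)cc2c1=O`, differs from compound 3 in one place: fluoro in place of methoxy on an aromatic carbon. Going by the values given here, the step from compound 2 to compound 3 bears on this most closely, since it is the methoxy on the ring of carbon only that is now exchanged for fluoro; no measured pair shows fluoro against hydrogen or against methoxy. Taking away that methoxy would be expected to undo part of the drop seen from compound 2 to compound 3, while the fluoro remains an unknown; a modest rise in number, beyond the scatter but not back to compound 2, is expected, as a 2.1-fold higher number from compound 3 to compound 4 (0.33 log units; beyond the scatter). Compound 4 is therefore estimated at 45000 nM, within 20000 nM to 100000 nM.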

Compound 4, half-maximal inhibitory concentration: 36000 nM
For compound 4 the middle estimate is 1.3-fold (0.10 log units) above the measured one; the range from low to high includes it.
By their numbers in this assay, from the lowest: compounds 3 and 4 (each within the scatter of the next); then compounds 2 and 1 (each within the scatter of the next).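

At this place, on an aromatic carbon of a six-membered aromatic ring of carbon only and para to a large group, hydrogen now has a second replacement: fluoro in place of hydrogen gives a 2.1-fold lower number from compound 2 to compound 4 (0.31 log units; beyond the scatter). The lower number at this place is therefore not tied to methoxy alone, at least among compounds 2, 3 and 4. In this assay, fluoro in place of methoxy gives a 1.7-fold higher number from compound 3 to compound 4 (0.23 log units; within the scatter), so the two groups cannot be told apart here, even though 1 heavy atom and 0 hydrogen-bond acceptors enter where 2 heavy atoms and 1 hydrogen-bond acceptor leave.

Nothing available explains why the number moves at this place or why these two groups read alike. As far as these compounds go, it remains open whether an amine, a carboxylic acid or a chloro group at this place would stay with compound 3 and compound 4 or return to the level of compound 2, and whether fluoro would lower the number on the core of compound 1 as methoxy does.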